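This account rests on a few compounds, and the source may have more. Where it says the series, first, only, none or still open, it means among the compounds named here.

Measured so far in the series:
compound 1 `CC1=C(C(=O)Nc2ccc(Br)cc2)C(c2ccc(Cl)cc2Cl)N=C(SCc2ccccc2)N1` gives 17.4%
compound 2 `COc1ccc(C2N=C(SCc3ccccc3)NC(C)=C2C(=O)Nc2ccc(Br)cc2)cc1` gives 11.3%

Both numbers come from a functional assay on the whole organism (artery, strain albino) with Rattus norvegicus as the target, with a stated time of 600 min, at a dose of 10 mg/kg by the oral route; a lower number here means less inhibition, a higher number more inhibition at the dose given (going by the name of the read-out). Compound 2 gives 11.3% and compound 1 gives 17.4%; the two values lie within the scatter of each other, so neither compound can be placed above the other on these data. For the measured compounds named here, the one measured step, a number 6.1 percentage points lower from compound 1 to compound 2 (within the scatter), concerns the aryl on the saturated ring carbon and leaves the benzylsulfanyl group untouched.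

Compound 3 `COc1ccc(C2N=C(SCc3ccc(Cl)cc3)NC(C)=C2C(=O)Nc2ccc(Br)cc2)cc1` differs from compound 2 by chloro in place of hydrogen on an aromatic carbon. Going by the values given here, no measured step touches this ring, so nothing points to a direction for the change; the only step available, at another site, stayed within the scatter. For compound 3 the expected step is a number 0.7 percentage points higher from compound 2 to compound 3 (within the scatter), that is, none beyond the scatter. Compound 3 is estimated at 12%, with a range from 0% to 30%.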

Compound 3, a percentage reported as inhibition, in the whole organism at one dose (the size of the read-out at that dose, not a potency): 30.3%
Compound 3: middle estimate off by 18.3 percentage points, on the low side; the whole stated range lies below it.
By their numbers in this assay, from the lowest: compounds 2 and 1 (each within the scatter of the next); then compound 3.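

In this assay, for the compounds shown here, phenyl to 4-chlorophenyl within the benzylsulfanyl group gives a number 19 percentage points higher from compound 2 to compound 3 (beyond the scatter), the first single change to pass the scatter. The benzyl ring, untouched in the earlier step, therefore responds to substitution: one chloro, para to a large group, is enough to shift the read-out at this dose, although this rests on a single pair carrying the 4-methoxyphenyl group. No measurement at hand bears on why the number moved.

From the compounds shown here alone, whether the rise is particular to chloro or also appears with fluoro, an amine or a carboxylic acid at the same place remains open. Also open, going by these compounds, are whether chloro has the same effect alongside the 2,4-dichlorophenyl group of compound 1 and how a longer chain in place of benzyl would read.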